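A few compounds are considered here, and "the series" means these few. Any claim that something is new, unique, unknown or untested is made for them only; others in the source may bear on it.

Measured compounds:
compound 1, `CNC(=O)CCn1nc(-c2ccccc2)ccc1=O` — 3.5% in a functional assay on the whole organism (stomach) for inhibition, with Rattus norvegicus as the target, at a dose of 100 mg/kg by the intraduodenal route; on this read-out higher numbers stand for more inhibition at the one dose given (going by the name of the read-out) and lower numbers for less inhibition
compound 2, `CC(CC(=N)S)n1nc(-c2ccccc2)ccc1=O` — 15.5%

Among the measured compounds shown here, compound 1 stands lowest of the two numbers; the only step known, a number 12 percentage points higher from compound 1 to compound 2 (beyond the scatter), alters the chain on the aromatic nitrogen, not the carbonyl. Compound 3, `CCOC(=O)CCn1nc(-c2ccccc2)ccc1=O`, differs from compound 1 by ethoxy in place of methylamino on a carbonyl carbon. For the measured compounds named here, no measured step bears on this change, so no direction beyond the scatter is expected. Compound 3 is therefore estimated to give 8% (range 0% to 25%), a step of a number 4.5 percentage points higher from compound 1 to compound 3 (within the scatter) that is expected to stay within the scatter.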

Compound 3, a percentage reported as inhibition, in the whole organism at one dose (the size of the read-out at that dose, not a potency): 6.3%
Compound 3: the middle estimate sits 1.7 percentage points above what was measured, within the range that was stated.
By their numbers in this assay, from the lowest: compounds 1, 3 and 2 (each within the scatter of the next, the first and the last beyond it).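

On a carbonyl carbon whose other neighbour is a saturated chain carbon, ethoxy in place of methylamino gives a number 2.8 percentage points higher from compound 1 to compound 3 (within the scatter) in this assay. The exchange therefore removes the hydrogen-bond donor of methylamino and adds a hydrogen-bond acceptor, with no step beyond the scatter on this read-out. No available evidence offers an explanation for this result. The compounds shown leave open how a carboxylic acid or a primary amide would read on this carbonyl carbon. They also leave open whether a longer chain in place of ethoxy would read differently.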